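Swapping the Aryl Group on the Piperazine of Compound 1

A few compounds are considered here, and "the series" means these few. Any claim that something is new, unique, unknown or untested is made for them only; others in the source may bear on it.

Compound 1, with the structure `COC(=O)C1=C(C)NC(=O)N(C(=O)NCCCN2CCN(c3ccc(OC)cc3C)CC2)C1c1ccc(F)c(F)c1`, was tested in an assay on liver for binding affinity to Alpha-1D adrenergic receptor (Homo sapiens), using microsomes (a higher number here means a weaker inhibitor, a lower number a stronger inhibitor), where compound 1 gives 610 nM. A second compound, compound 2 with the structure `COCC1=C(C(=O)OC)C(c2cc(F)c(F)cc2F)N(C(=O)NCCCN2CCN(c3ccccc3C(N)=O)CC2)C(=O)N1`, differs from compound 1 in several parts of the molecule at once, so no single change links the two. In this assay compound 2 gives 190 nM. Of the two measured numbers, compound 1 has the higher one, meaning the weaker binding, and the gap between them lies beyond the usual scatter.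

Compound 3, with the structure `COC(=O)C1=C(C)NC(=O)N(C(=O)NCCCN2CCN(c3ccc(Cl)cc3)CC2)C1c1ccc(F)c(F)c1`, has not yet been measured. It differs from compound 1 in one place: 4-chlorophenyl in place of 4-methoxy-2-methylphenyl on an amine nitrogen in a ring.

Within the data shown here, no measured pair in this set shows what such a change on the amine nitrogen in the ring does, so the expectation rests on compound 1 alone. The expected step from compound 1 to compound 3 in this assay is a 1.1-fold higher number from compound 1 to compound 3 (0.06 log units; within the scatter), which is small and within the scatter. For compound 3 the estimated value in this assay is 700 nM, with a range from 250 nM to 2000 nM.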

Compound 3, inhibition constant: 52 nM
Compound 3: the middle estimate sits 13-fold (1.13 log units) above what was measured; the measured number lies below the stated range.
By their numbers in this assay, from the lowest: compound 3; then compound 2; then compound 1.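

In this assay, the exchange of 4-methoxy-2-methylphenyl for 4-chlorophenyl on the amine nitrogen in the ring gives a 12-fold lower number from compound 1 to compound 3 (1.07 log units; beyond the scatter) and leaves the rest of the molecule untouched. Among these compounds, this is the first comparison in the set that isolates a single site, and it shows that the group on this nitrogen has a large effect on the measured binding, something the comparison of compound 1 with compound 2 could not show because those two differ in several parts at once. The exchange alters more than one feature, since the methoxy and methyl groups leave, chlorine enters and the group goes from 9 heavy atoms to 7, and no measurement here accounts for the size of the step.

As far as these compounds go, it remains open whether the gain comes from adding the chlorine or from losing the methoxy or the methyl group, a question that plain phenyl, 4-methoxyphenyl and 2-methylphenyl on the same nitrogen could help separate. Also open, from the compounds shown here alone, is whether 4-fluorophenyl or 4-bromophenyl would behave like 4-chlorophenyl, and whether the same exchange would carry over to the differently substituted core of compound 2.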